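The source may report more compounds than this note shows. Statements on the series, on what has been measured and on what is new or still open speak of the compounds shown alone.

Measured so far in an assay on isolated protein for inhibition of Indoleamine 2,3-dioxygenase 1 (Homo sapiens), with a stated time of 60 min, tested at 10 uM; a higher number here means more inhibition at the concentration tested (going by the name of the read-out), a lower number less inhibition:
compound 1, `Clc1ccc2[nH]c(SCc3ccccc3/C=C\c3ccccc3)nc2c1`, gives 49%
compound 2, `Clc1ccc2[nH]c(SCc3ccccc3CCCc3ccccc3)nc2c1`, gives 19%

Compound 2 stands lowest of the two numbers in this assay; its nearest neighbour is compound 1, and the step of a number 30 percentage points lower from compound 1 to compound 2 (beyond the scatter) is beyond the scatter, so the two compounds are ordered. That step is the only measured one in the series, and it concerns the chain on the aromatic carbon of the shared core.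

Compound 3, `Clc1ccc2[nH]c(SCc3ccccc3SCc3ccccc3)nc2c1`, is not yet measured. It differs from compound 2 in one place: benzylsulfanyl in place of 3-phenylpropyl on an aromatic carbon. Going by the values given here, the step from compound 1 to compound 2 bears on it only loosely, since it shows that this position is sensitive to what sits on it, but no measured pair shows what replacing the 3-phenylpropyl chain by benzylsulfanyl does. A change of any size in either direction in this assay is therefore possible; with compound 2 near the low end, a move upward has more room than a move downward.

The estimate for compound 3 is 30% in this assay, within 5% to 60%, that is an expected step of a number 11 percentage points higher from compound 2 to compound 3 (beyond the scatter), barely beyond the scatter.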

Compound 3, a percentage reported as inhibition, at one concentration (the size of the read-out at that concentration, not a potency): 19%
Estimate against measurement, compound 3: 11 percentage points above; the range from low to high includes it.
By their numbers in this assay, from the lowest: compounds 2 and 3 (each within the scatter of the next); then compound 1.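

In this assay, benzylsulfanyl in place of 3-phenylpropyl gives no change at the digits printed from compound 2 to compound 3 (within the scatter) even though benzylsulfanyl carries a sulfur and a hydrogen-bond acceptor that 3-phenylpropyl lacks, so this change on the aromatic carbon separates neither the two groups nor the two compounds. Replacing 2-phenylethenyl with benzylsulfanyl gives a number 30 percentage points lower from compound 1 to compound 3 (beyond the scatter) and so matches the earlier step, which means the lower number is not confined to the 3-phenylpropyl chain and, among these three compounds, compound 1 alone stands apart. No supporting data bear on why these groups read as they do.

As far as these compounds go, what remains open is whether the higher number of compound 1 belongs to 2-phenylethenyl alone or would also appear with a benzyloxy or a benzylamino group on this aromatic carbon. Each number is also a reading at one concentration, so these compounds leave open whether compounds 2 and 3 would still read alike across a range of concentrations.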